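This account rests on a few compounds, and the source may have more. Where it says the series, first, only, none or still open, it means among the compounds named here.

Going by the values given here, compound 1 `FC(F)(F)c1ccc(CSc2nc(N3CCCCC3)c3ccccc3n2)cc1` gives 25500 nM in a functional assay on PC-3 cells (Homo sapiens) for cytotoxicity, read by MTT assay, with a stated time of 72 h (a higher number here means a weaker inhibitor, a lower number a stronger inhibitor), the second highest of the three numbers measured so far, though all three sit within the scatter of one another. Compound 2 `Cc1ccc(Nc2nc(SCc3ccc(C(F)(F)F)cc3)nc3ccccc23)cc1` gives 21100 nM and compound 3 `CCOc1ccc(Nc2nc(SCc3ccc(C(F)(F)F)cc3)nc3ccccc23)cc1` gives 32100 nM; the step of a 1.2-fold lower number from compound 1 to compound 2 (0.08 log units; within the scatter) and the step of a 1.3-fold higher number from compound 1 to compound 3 (0.10 log units; within the scatter) are both within the scatter. Compound 4 `COc1cc(Nc2nc(SCc3ccc(C(F)(F)F)cc3)nc3ccccc23)cc(OC)c1` differs from compound 1 in one place: (3,5-dimethoxyphenyl)amino in place of piperidin-1-yl on an aromatic carbon. The two steps that put (4-methylphenyl)amino and (4-ethoxyphenyl)amino in place of piperidin-1-yl bear on this change, and neither moved the number beyond the scatter, so no step beyond the scatter is expected in this assay, which is a 1.0-fold higher number from compound 1 to compound 4 (0.01 log units; within the scatter). Compound 4 is therefore estimated at 26000 nM, with a range from 12000 nM to 55000 nM.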

Compound 4, half-maximal inhibitory concentration: > 50000 nM
Compound 4 ended at the assay's limit; the forecaster's own chance of this, stated with the estimate: 10%; middle value at least 1.9-fold (0.28 log units) from the limit.
By their numbers in this assay, from the lowest: compounds 2, 1 and 3 (each within the scatter of the next). At a limit, above all of these: compound 4.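

Compound 4 stands at a limit of the assay, not at a measured number: the limit of > 50000 nM in this assay, at which 1 of the 4 values shown sits. Placing 3,5-dimethoxyphenyl in place of 4-methylphenyl on the nitrogen gives an at least 2.3-fold higher number from compound 2 to compound 4 (0.37 log units; beyond the scatter), the first step in this set beyond the scatter, so the groups on this aromatic ring can affect the read-out. The other two steps, an at least 1.9-fold higher number from compound 1 to compound 4 (0.29 log units; that floor lies within the scatter) and an at least 1.5-fold higher number from compound 3 to compound 4 (0.19 log units; that floor lies within the scatter), have floors that show no firm change.

From the compounds shown here alone, how far compound 4 lies past its limit stays open. So does the effect of a single methoxy group, a carboxylic acid or an amine on that ring.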